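This account rests on a few compounds, and the source may have more. Where it says the series, first, only, none or still open, it means among the compounds named here.

Compound 3 `COc1cccc(CNCCCNc2ccnc3cc(Cc4ccc(C#N)cc4)ccc23)c1O` gives 4200 nM in a physicochemical assay for solubility, with a stated time of 18 h, at pH 7.4; on this read-out lower numbers stand for lower solubility and higher numbers for higher solubility. Compound 1 `COc1cccc(CNCCCNc2ccnc3cc(Cc4ccc(F)cc4)ccc23)c1O` gives 4200 nM in this assay, and the step of no change at the digits printed from compound 1 to compound 3 (within the scatter) leaves the two level, together the lowest of the three numbers. Going by the values given here, compound 2 `COc1ccc(Oc2ccc3c(NCCCNCc4cccc(OC)c4O)ccnc3c2)cc1` gives 14500 nM in this assay, the highest of the three; the step of a 3.5-fold higher number from compound 1 to compound 2 (0.54 log units; beyond the scatter) and the step of a 3.5-fold lower number from compound 2 to compound 3 (0.54 log units; beyond the scatter) are the only steps in the set beyond the scatter.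

Compound 4 `COc1cccc(CNCCCNc2ccnc3cc(-c4ccc(C(F)(F)F)cc4)ccc23)c1O` differs from compound 3 in one place: 4-(trifluoromethyl)phenyl in place of 4-cyanobenzyl on an aromatic carbon. Among the compounds with values here, no measured step covers this change directly. The step of no change at the digits printed from compound 1 to compound 3 (within the scatter) shows that exchanging the cyano for a fluoro, with the rest of the 4-cyanobenzyl group kept, left this assay unchanged. The steps of a 3.5-fold higher number from compound 1 to compound 2 (0.54 log units; beyond the scatter) and a 3.5-fold lower number from compound 2 to compound 3 (0.54 log units; beyond the scatter) show that exchanging the whole group at this position moved this assay by a modest amount. The change to compound 4 again exchanges the whole group, so a modest step at most is expected, downward if any, with a fair chance of none beyond the scatter. For compound 4 a value of 2500 nM is expected, within 800 nM to 8000 nM. The step this estimate means, a 1.7-fold lower number from compound 3 to compound 4 (0.23 log units; within the scatter), is expected to stay close to the scatter.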

Compound 4, solubility: 32000 nM
Compound 4: middle estimate off by 13-fold (1.11 log units), on the low side, outside the stated range (above it).
By their numbers in this assay, from the lowest: compounds 1 and 3 (each within the scatter of the next); then compound 2; then compound 4.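

In this assay, a phenyl group carrying trifluoromethyl at this position gives a 7.6-fold higher number from compound 3 to compound 4 (0.88 log units; beyond the scatter), and the same exchange against the fluoro analogue gives a 7.6-fold higher number from compound 1 to compound 4 (0.88 log units; beyond the scatter), so a whole-group exchange here can move the number upward well beyond what the two benzyl compounds suggested, and the nitrile-to-fluoro exchange, which left the number level, gave no guide to this. With a 2.2-fold higher number from compound 2 to compound 4 (0.34 log units; beyond the scatter), the 4-(trifluoromethyl)phenyl group also stands above the 4-methoxyphenoxy group, which makes compound 4 the highest of the four and shows that the position spans a wider range than the first three compounds showed. No measurement in hand explains the rise, and no cause can be assigned to it.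

Compound 4 changes both the group attached to the aromatic carbon and its ring substituent, so the shift from benzyl to phenyl cannot be separated from the exchange of nitrile for trifluoromethyl. A 4-cyanophenyl group would separate the two, while an amine or a carboxylic acid on the same ring would show whether the upward step holds for groups of another kind.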